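Chain lengthening in the series: cytotoxicity notes

This account rests on a few compounds, and the source may have more. Where it says the series, first, only, none or still open, it means among the compounds named here.

Measured so far:
compound 1, `CCCCCCc1ccc(-c2cc3cn([C@H]4C[C@H](O)[C@@H](CO)O4)c(=O)nc3o2)nc1`: > 50000 nM
compound 2, `CCCCCc1ccc(-c2cc3cn([C@H]4C[C@H](O)[C@@H](CO)O4)c(=O)nc3o2)cn1`: > 50000 nM

In an ADME assay on HEL cells (Homo sapiens) for cytotoxicity, with a stated time of 3 days (a higher number here means that more compound is tolerated, a lower number that less compound is tolerated), compound 1 gives only a limit, reported as > 50000 nM. In this assay compound 2 likewise gives only a limit, > 50000 nM. Compound 2 therefore stands at the ceiling of the numbers shown, alongside the one other value: the limit of > 50000 nM in this assay, at which 2 of the 2 values shown sit. Among the measured compounds shown here, no step between the measured compounds can be read, since compound 1 and compound 2 do not differ at a single site.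

Compound 3, `CCCCCCc1ccc(-c2cc3cn([C@H]4C[C@H](O)[C@@H](CO)O4)c(=O)nc3o2)cn1`, is not yet measured. It differs from compound 2 by methyl in place of hydrogen on a saturated chain carbon, five bonds along the chain from an aromatic carbon. In this assay no step beyond the scatter is expected from this change, in either direction. Compound 3 is thus expected to come in around 60000 nM, with a range from 30000 nM to 150000 nM, and most probably again as a limit only. The expected step that the limit leaves unreadable from compound 2 to compound 3 is essentially flat.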

Compound 3, half-maximal cytotoxic concentration: > 50000 nM
Compound 3 was reported as a limit; the forecaster's own chance of this, stated with the estimate: 85%; the middle value lies beyond the limit too.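

Compound 2 and compound 3 both stand only as limits in this assay, so no step can be read between them: the limit of > 50000 nM in this assay, at which 3 of the 3 values shown sit.

The compounds shown leave open at what concentration cytotoxicity sets in, and whether methyl in place of hydrogen on the chain shifts it at all.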